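This account rests on a few compounds, and the source may have more. Where it says the series, first, only, none or still open, it means among the compounds named here.

Notes on the stilbene-type series sharing the core of compound 1 `COc1cc(OC)c2c(=O)cc(/C=C/c3ccc(OCC4CC4)cc3)oc2c1`, with compound 2 `COc1cc(OC)c2c(=O)cc(/C=C/c3ccc(Cl)cc3)oc2c1` and compound 3 `COc1ccc(/C=C/c2cc(=O)c3c(OC)cc(OC)cc3o2)cc1` as the other measured members.

In a functional assay on PC-3 cells (Homo sapiens) for antiproliferative activity, read by MTT assay, with a stated time of 12 h (on this read-out higher numbers stand for weaker inhibition and lower numbers for stronger inhibition), compound 3 gives > 40000 nM, which is a limit of the assay and not a number. In this assay compound 1 gives > 40000 nM, again a limit. Compound 2 gives > 40000 nM in this assay, also a limit. Every measured value in the series therefore sits at the limit of > 40000 nM in this assay, at which 3 of the 3 values shown sit, so the three steps among them, a step that the two limits leave unreadable from compound 1 to compound 2, a step that the two limits leave unreadable from compound 1 to compound 3 and a step that the two limits leave unreadable from compound 2 to compound 3, carry no readable size.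

Compound 4 `COc1cc(OC)c2c(=O)cc(/C=C/c3ccc(Br)cc3)oc2c1` is not yet measured. It differs from compound 3 by bromo in place of methoxy on an aromatic carbon. The step from compound 2 to compound 3, a chloro-to-methoxy exchange on the same aromatic carbon, is the closest counterpart, and it is unreadable. Compound 4 is thus expected to give 50000 nM in this assay, with a range of 20000 nM to 150000 nM, most likely reported only as a limit. The step from compound 3 to compound 4 is expected to read a step that the limit leaves unreadable from compound 3 to compound 4.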

Compound 4, half-maximal inhibitory concentration: > 40000 nM
Compound 4 was reported as a limit; the forecaster's own chance of this, stated with the estimate: 85%; the middle value lies beyond the limit too.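

Among these compounds, compound 4 also sits at a limit and not at a number, so no step from compound 1, compound 2 or compound 3 to compound 4 can be read: the limit of > 40000 nM in this assay, at which 4 of the 4 values shown sit.

The compounds shown leave open whether any group on this aromatic carbon of the shared core would give a readable value in this assay.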